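The compounds below may be only part of what the source reports. "The series", "measured", "known", "first", "only" and "open" are said of these compounds alone.

In a functional assay on HCT-116 cells (Homo sapiens) for cytotoxicity, read by MTT assay, with a stated time of 48 h (a lower number here means a stronger inhibitor of growth, a higher number a weaker inhibitor of growth), compound 1 `Cc1nc2cc(Cl)c(Cl)cc2[nH]1` gives 51000 nM and compound 2 `CC(C)c1nc2cc(Cl)c(Cl)cc2[nH]1` gives 52000 nM. Compound 3 `Cc1nc2cc(Cl)c(Cl)cc2n1C1CCCC1` gives 13000 nM, the lowest of the three numbers and beyond the scatter from both of the others.

Compound 4 `C[S+]([O-])c1nc2cc(Cl)c(Cl)cc2n1C1CCCC1` has not yet been measured. It differs from compound 3 in one place: a group of 3 heavy atoms (1 carbon, 1 oxygen, 1 sulfur; no ring) in place of one carbon atom, on an aromatic carbon. The change sits on an aromatic carbon between two ring nitrogen atoms, next to the ring atom that bears a cyclopentyl group.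

For the measured compounds named here, two measured steps bear on this. The closer one is a change at this same carbon, isopropyl in place of methyl, which gave a 1.0-fold higher number from compound 1 to compound 2 (0.01 log units; within the scatter). The other, cyclopentyl in place of hydrogen on an aromatic nitrogen, gave a 3.9-fold lower number from compound 1 to compound 3 (0.59 log units; beyond the scatter), a modest step that compound 4 keeps, so its number is expected to stay near that of compound 3 rather than return to that of compound 1.

Going by the values given here, no measured compound carries oxygen or sulfur at this carbon, so the direction remains open and the expectation is uncertain. No step beyond the scatter is expected, and the estimate is a 1.2-fold higher number from compound 3 to compound 4 (0.06 log units; within the scatter). For compound 4 the estimated value is 15000 nM, with an expected range from 5000 nM to 45000 nM.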

Compound 4, concentration for 50% growth inhibition: 500 nM
Compound 4: middle estimate off by 30-fold (1.48 log units), on the high side, and the stated range ends above it.
By their numbers in this assay, from the lowest: compound 4; then compound 3; then compounds 1 and 2 (each within the scatter of the next).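

This position turns out to be far from indifferent to what it carries. In this assay, for the compounds shown here, the only earlier change at this aromatic carbon, isopropyl in place of methyl, gave a 1.0-fold higher number from compound 1 to compound 2 (0.01 log units; within the scatter), which might suggest that the carbon hardly matters, yet replacing methyl with the group of carbon, oxygen and sulfur gives a 26-fold lower number from compound 3 to compound 4 (1.41 log units; beyond the scatter). That step is also larger than the one gained by adding cyclopentyl on the ring nitrogen, a 3.9-fold lower number from compound 1 to compound 3 (0.59 log units; beyond the scatter), so among the compounds shown, the change at this carbon does more to lower the number than the change on the nitrogen, although no measurement shown accounts for the size of the new step.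

The compounds shown leave open which part of the new group matters, and a methylthio group, with sulfur but no oxygen, or a methylsulfonyl group, with a second oxygen on the sulfur, would help separate the roles of the two atoms. They also leave open whether the same group lowers the number without the cyclopentyl group, on the core of compound 1, and how an amine at this carbon would compare.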